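The source may report more compounds than this note shows. Statements on the series, on what has been measured and on what is new or still open speak of the compounds shown alone.

Compound 1 `Cc1cc(-c2ccc(C#N)cc2)cc(C)c1Nc1ccnc(Nc2ccc(C#N)cc2)n1` is one of three compounds tested in an ADME assay on MT4 cells (Homo sapiens) for cytotoxicity, read by MTT assay, with a stated time of 4 days (on this read-out lower numbers stand for higher toxicity in this test and higher numbers for lower toxicity in this test), where compound 1 gives 2080 nM. Compound 2 `Cc1cc(-c2ccccc2Cl)cc(C)c1Nc1ccnc(Nc2ccc(C#N)cc2)n1` gives 3990 nM in this assay, and compound 3 `Cc1cccc(-c2cc(C)c(Nc3ccnc(Nc4ccc(C#N)cc4)n3)c(C)c2)c1` gives 3670 nM. Compound 1 has the lowest of the three numbers, yet the step of a 1.9-fold higher number from compound 1 to compound 2 (0.28 log units; within the scatter) and the step of a 1.8-fold higher number from compound 1 to compound 3 (0.25 log units; within the scatter) both stay within the scatter, as does the step of a 1.1-fold lower number from compound 2 to compound 3 (0.04 log units; within the scatter), so the three compounds cannot be separated on these numbers.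

Compound 4 `Cc1ccc(-c2cc(C)c(Nc3ccnc(Nc4ccc(C#N)cc4)n3)c(C)c2)cc1` has not yet been measured in this assay. It differs from compound 1 by methyl in place of cyano on an aromatic carbon. The two measured steps that bear on this change are those that alter the same ring of compound 1, namely 2-chlorophenyl in place of 4-cyanophenyl and 3-methylphenyl in place of 4-cyanophenyl. Both moved the number upward by an amount that stays within the scatter. A change of the same ring to 4-methylphenyl is expected to behave alike, so a step of a 1.6-fold higher number from compound 1 to compound 4 (0.20 log units; within the scatter) is estimated, no larger than the scatter. Compound 4 is therefore expected to give about 3300 nM in this assay, within a range from 1700 nM to 6500 nM.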

Compound 4, half-maximal cytotoxic concentration: 5570 nM
Compound 4: middle estimate off by 1.7-fold (0.23 log units), on the low side; measured number inside the range.
By their numbers in this assay, from the lowest: compounds 1, 3, 2 and 4 (each within the scatter of the next, the first and the last beyond it).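

In this assay, the step of a 2.7-fold higher number from compound 1 to compound 4 (0.43 log units; beyond the scatter) is the only one among the compounds shown to pass beyond the scatter, a modest shift towards lower toxicity in this test, whereas the earlier changes to this same ring did not separate any pair. The shift is tied to compound 1 alone, as the step of a 1.5-fold higher number from compound 3 to compound 4 (0.18 log units; within the scatter) and the step of a 1.4-fold higher number from compound 2 to compound 4 (0.14 log units; within the scatter) both stay within the scatter, so 4-methylphenyl cannot be told apart from 3-methylphenyl or 2-chlorophenyl on these numbers. No measurement given here accounts for the difference between cyano and methyl at this place.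

The compounds shown leave open whether the higher number goes with methyl itself or simply with the loss of the nitrile, since only these two groups are compared on an aromatic carbon para to a large group. An amine, a carboxylic acid or a longer chain such as ethyl at that place would show whether the number follows the group that enters or only the departure of cyano.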